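Sulfanyl in place of dimethylamino in a weak series

The compounds below may be only part of what the source reports. "The series", "measured", "known", "first", "only" and "open" are said of these compounds alone.

Measured in a functional assay on L1210 cells (Mus musculus) for inhibition; a higher number here means a weaker inhibitor, a lower number a stronger inhibitor:
compound 1 `C=C1[C@@H](O)[C@H](n2cnc3c(Cl)nc(N)nc32)O[C@@H]1CO` gives 441000 nM
compound 2 `C=C1[C@@H](O)[C@H](n2cnc3c(O)nc(N)nc32)O[C@@H]1CO` has a limit, > 200000 nM
compound 3 `C=C1[C@@H](O)[C@H](n2cnc3c(N(C)C)nc(N)nc32)O[C@@H]1CO` has a limit, > 500000 nM

Compound 3 stands only at a limit (> 500000 nM) and has no number. Compound 4 `C=C1[C@@H](O)[C@H](n2cnc3c(S)nc(N)nc32)O[C@@H]1CO` carries sulfanyl in place of dimethylamino on an aromatic carbon. Three measured steps at this place bear on the change. One is an at least 1.1-fold higher number from compound 1 to compound 3 (0.05 log units; that floor lies within the scatter) and the others are a step that the limit leaves unreadable from compound 1 to compound 2 and a step that the two limits leave unreadable from compound 2 to compound 3 and give no size. Within the data shown here, compound 1 holds the only true number (441000 nM) and so anchors the expectation at the weak end. Expected in this assay is an at least 2.5-fold lower number from compound 3 to compound 4 (0.39 log units; beyond the scatter) toward a lower number, and a modest one. Compound 4 is estimated at 200000 nM (range 40000 nM to 600000 nM).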

Compound 4, half-maximal inhibitory concentration: 207000 nM
The estimate for compound 4 lay 1.0-fold (0.01 log units) below the measured number; the measured number falls inside the stated range.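

In this assay, among these compounds, the change to sulfanyl gives the only step at this position with a readable size beyond the scatter: a 2.1-fold lower number from compound 1 to compound 4 (0.33 log units; beyond the scatter). Against dimethylamino there is an at least 2.4-fold lower number from compound 3 to compound 4 (0.38 log units; beyond the scatter), which is only a floor, and the step from compound 2 to compound 4 cannot be read. Compound 3 has only a limit and no number: the limit of > 500000 nM in this assay, at which 1 of the 4 values shown sits.

Going by these compounds, whether a primary amine or methylsulfanyl at this place would move the number further stays open. So does whether any group here would take the shared core out of this weak range.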